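The source may hold more compounds than are shown below. What is called first, only, known or untested is meant among the compounds shown, and "the series" means these compounds.

Two compounds of the series carry a measured number. Compound 1 `COc1cc2c(Oc3ccc(NC(=O)c4nnn(-c5ccccc5C)c4C)cc3F)ccnc2cc1OCCCN1CCCC1` in a functional assay on U-87MG ATCC cells (Homo sapiens) for cytotoxicity, read by MTT assay, with a stated time of 72 h (on this read-out higher numbers stand for weaker inhibition and lower numbers for stronger inhibition), gives 1600 nM. Compound 2 `COc1cc2c(Oc3ccc(NC(=O)c4nnn(-c5ccccc5C)c4C)cc3F)ccnc2cc1OCCCN1CCCCC1` gives 2370 nM in this assay. Among the measured compounds shown here, the only step between them, a 1.5-fold higher number from compound 1 to compound 2 (0.17 log units; within the scatter), exchanges the terminal amine ring of the chain and stays within the scatter. Compound 2 therefore holds the higher of the two numbers, but the gap to compound 1 is within the scatter, so no order between the two is established.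

Compound 3 `COc1cc2c(Oc3ccc(NC(=O)c4nnn(-c5ccccc5C)c4C)cc3F)ccnc2cc1OCCCN1CCC(C)CC1` is not yet measured in this assay. It differs from compound 2 by methyl in place of hydrogen on a saturated ring carbon, three ring bonds from the ring nitrogen. For the measured compounds named here, no measured step touches a substituent on that ring carbon; the one available step, a 1.5-fold higher number from compound 1 to compound 2 (0.17 log units; within the scatter), concerns the ring size and lay within the scatter. On that basis no step beyond the scatter is expected from compound 2 to compound 3, so the estimated step is a 1.1-fold higher number from compound 2 to compound 3 (0.06 log units; within the scatter). For compound 3 the expected value in this assay is 2700 nM, with a range from 1100 nM to 6500 nM.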

Compound 3, half-maximal inhibitory concentration: 2160 nM
Estimate against measurement, compound 3: 1.3-fold (0.10 log units) above, within the range that was stated.
By their numbers in this assay, from the lowest: compounds 1, 3 and 2 (each within the scatter of the next).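

Methyl in place of hydrogen on a saturated ring carbon, three ring bonds from the ring nitrogen, is the first measured change on this ring carbon, and in this assay it gives a 1.1-fold lower number from compound 2 to compound 3 (0.04 log units; within the scatter), so the added methyl leaves compound 3 and compound 2 within the scatter of each other. The exchange of pyrrolidin-1-yl for 4-methylpiperidin-1-yl gives a 1.4-fold higher number from compound 1 to compound 3 (0.13 log units; within the scatter), so all three terminal amine rings shown now lie within the scatter of one another, and neither ring size nor this methyl separates any pair in this assay. No measurement on hand offers an explanation for how closely these numbers lie.

From the compounds shown here alone, it remains open whether a larger group or a hydroxyl on this ring carbon, or a morpholine ring or a dimethylamino group at the end of the chain, would give a step beyond the scatter. Also open, going by these compounds, is whether a longer or shorter chain carrying the same piperidin-1-yl or 4-methylpiperidin-1-yl end would leave the number within the scatter.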